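This account rests on a few compounds, and the source may have more. Where it says the series, first, only, none or still open, it means among the compounds named here.

Compound 1 `N#Cc1c(Cl)nc(SCc2nc3ccccc3[nH]2)nc1-c1ccccc1` carries a chloro group on the shared core. In a functional assay on NCI-H460 cells (Homo sapiens) for cytotoxicity, read by MTT assay, with a stated time of 3 days (on this read-out lower numbers stand for stronger inhibition and higher numbers for weaker inhibition), compound 1 gives 3.28 nM, the second highest of the three numbers shown, though within the scatter of both compound 3 `N#Cc1c(NNC(N)=S)nc(SCc2nc3ccccc3[nH]2)nc1-c1ccccc1`, which gives 3.37 nM, and compound 2 `N#Cc1c(Nc2ccccn2)nc(SCc2nc3ccccc3[nH]2)nc1-c1ccccc1`, which gives 2.8 nM. Compound 4 `N#Cc1c(NC(N)=O)nc(SCc2nc3ccccc3[nH]2)nc1-c1ccccc1` differs from compound 1 in one place: ureido in place of chloro on an aromatic carbon. Going by the values given here, two measured steps bear on this, since each likewise replaces that chloro group: a 1.2-fold lower number from compound 1 to compound 2 (0.07 log units; within the scatter) and a 1.0-fold higher number from compound 1 to compound 3 (0.01 log units; within the scatter). Both steps lie within the scatter, so for the ureido group no step beyond the scatter is expected in this assay either. Compound 4 is therefore estimated to give about 3.3 nM, with a likely range from 1.5 nM to 7 nM. That estimate means a 1.0-fold higher number from compound 1 to compound 4 (0.00 log units; within the scatter).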

Compound 4, half-maximal inhibitory concentration: 14.7 nM
Beside the measured number, compound 4's estimate is 4.5-fold (0.65 log units) below it; measured number outside the range, above it.
By their numbers in this assay, from the lowest: compounds 2, 1 and 3 (each within the scatter of the next); then compound 4.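

The chloro position is not indifferent to what replaces it: a 4.5-fold higher number from compound 1 to compound 4 (0.65 log units; beyond the scatter) is a step beyond the scatter in this assay, whereas the two earlier replacements stayed within it. The ureido group also stands apart from those replacements, with a 5.3-fold higher number from compound 2 to compound 4 (0.72 log units; beyond the scatter) and a 4.4-fold higher number from compound 3 to compound 4 (0.64 log units; beyond the scatter) both pointing the same way. Nothing measured here gives a reason for this rise. From the compounds shown here alone, whether a plain amine or a methoxy group in place of chloro would stay level with compound 1 or rise like compound 4 remains open.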